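Methyl in place of halogen: paw edema inhibition notes

The source may report more compounds than this note shows. Statements on the series, on what has been measured and on what is new or still open speak of the compounds shown alone.

Measured so far:
compound 1 `Nc1cc(-c2ccc(Br)cc2)nc2cc(-c3ccc(Cl)cc3)nn12` — 60%
compound 2 `Cc1ccc(-c2cc3nc(-c4ccc(Br)cc4)cc(N)n3n2)cc1` — 56.3%

In a functional assay on the whole organism (strain Wistar) for inhibition, with Rattus norvegicus as the target, read by paw edema, with stated times of 30 min and 2 h, at a dose of 50 mg/kg by the oral route (on this read-out higher numbers stand for more inhibition at the one dose given (going by the name of the read-out) and lower numbers for less inhibition), compound 1 gives 60%, the higher of the two numbers, with compound 2 at 56.3% and the step of a number 3.7 percentage points lower from compound 1 to compound 2 (within the scatter). Compound 3 `Cc1ccc(-c2cc(N)n3nc(-c4ccc(Cl)cc4)cc3n2)cc1` differs from compound 1 by methyl in place of bromo on an aromatic carbon. Among the compounds with values here, the one measured step, a number 3.7 percentage points lower from compound 1 to compound 2 (within the scatter), also swaps a halogen for methyl and did not move the read-out beyond the scatter, so no step beyond the scatter is expected here either. Compound 3 is therefore expected to give about 57%, between 45% and 69%, an expected step of a number 3 percentage points lower from compound 1 to compound 3 (within the scatter).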

Compound 3, a percentage reported as inhibition, in the whole organism at one dose (the size of the read-out at that dose, not a potency): 75%
Beside the measured number, compound 3's estimate is 18 percentage points below it, outside the stated range (above it).
By their numbers in this assay, from the lowest: compounds 2 and 1 (each within the scatter of the next); then compound 3.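

Within the data shown here, the change from 4-bromophenyl to 4-methylphenyl gives a number 15 percentage points higher from compound 1 to compound 3 (beyond the scatter), the first step to clear the scatter. Methyl in place of chloro gives a number 3.7 percentage points lower from compound 1 to compound 2 (within the scatter), so the same kind of exchange does not read alike at the two halogen-bearing groups of the shared core. No measurement at hand bears on the reason for this gain.

Whether the gain is particular to methyl stays open, since the compounds shown include no ethyl, methoxy or amine group at this place. With one exchange at each halogen, no trend can be drawn yet.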